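From Ethyl to Cyclopropyl on an Aromatic Nitrogen

The compounds below may be only part of what the source reports. "The series", "measured", "known", "first", "only" and "open" are said of these compounds alone.

Of the compounds shown here, three sharing one core have been measured in a functional assay on DU-145 cells (Homo sapiens) for inhibition, read by trypan blue exclusion, with a stated time of 72 h; a lower number here means a stronger inhibitor, a higher number a weaker inhibitor. Compound 1 (`COC(=O)Cn1c(=O)c(S(=O)(=O)c2ccc(F)cc2F)cc2cnc(Nc3ccc4[nH]ccc4c3)nc21`), which carries (methoxycarbonyl)methyl on an aromatic nitrogen, gives 10000 nM. Compound 2 (`O=c1[nH]c2nc(Nc3ccc4[nH]ccc4c3)ncc2cc1S(=O)(=O)c1ccc(F)cc1F`), with hydrogen there, gives 15000 nM, and the data show a 1.5-fold higher number from compound 1 to compound 2 (0.18 log units; within the scatter). Compound 3 (`CCn1c(=O)c(S(=O)(=O)c2ccc(F)cc2F)cc2cnc(Nc3ccc4[nH]ccc4c3)nc21`), with ethyl there, gives 750 nM, the lowest of the three numbers. The measured steps towards it are a 20-fold lower number from compound 2 to compound 3 (1.30 log units; beyond the scatter) and a 13-fold lower number from compound 1 to compound 3 (1.12 log units; beyond the scatter).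

Compound 4 (`O=c1c(S(=O)(=O)c2ccc(F)cc2F)cc2cnc(Nc3ccc4[nH]ccc4c3)nc2n1C1CC1`) has cyclopropyl in place of ethyl on an aromatic nitrogen. The two large steps bear on this change only indirectly. They show that this assay can respond strongly to the group at this nitrogen, but they compare ethyl with hydrogen and with (methoxycarbonyl)methyl. Among the measured compounds shown here, no measured compound has a ring there. Ethyl and cyclopropyl are both groups of carbon only, so the closest reference is compound 3 at 750 nM, and no step beyond the scatter is expected in this assay. The expected result is a 1.1-fold higher number from compound 3 to compound 4 (0.03 log units; within the scatter). For compound 4 the estimated value is 800 nM, with an expected range from 250 nM to 3000 nM.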

Compound 4, half-maximal inhibitory concentration: 500 nM
Compound 4: middle estimate off by 1.6-fold (0.20 log units), on the high side; the measured number falls inside the stated range.
By their numbers in this assay, from the lowest: compounds 4 and 3 (each within the scatter of the next); then compounds 1 and 2 (each within the scatter of the next).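

In this assay, the first ring at this aromatic nitrogen leaves the number essentially unchanged (a 1.5-fold lower number from compound 3 to compound 4 (0.18 log units; within the scatter)), so the three-membered ring of carbon only can take the place of ethyl without a step beyond the scatter. The earlier compounds shown here could not show this, as none of them carried a ring at this position. Cyclopropyl also keeps the large separation first seen with ethyl, both from the hydrogen (a 30-fold lower number from compound 2 to compound 4 (1.48 log units; beyond the scatter)) and from (methoxycarbonyl)methyl (a 20-fold lower number from compound 1 to compound 4 (1.30 log units; beyond the scatter)), so two different groups of carbon only now stand apart from those two. Nothing available explains this result.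

The compounds shown leave open whether a longer chain such as propyl, or a larger ring of carbon only such as cyclobutyl, would stay level with compound 3 and compound 4 in this assay. Among the compounds shown here, they also leave open how a chain ending in an amine or a carboxylic acid would behave at this nitrogen, as compound 1 is the only one here whose group holds atoms other than carbon.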